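This account rests on a few compounds, and the source may have more. Where it says the series, first, only, none or still open, it means among the compounds named here.

Measured in a physicochemical assay for solubility, in the presence of a further agent that is not named here; on this read-out higher numbers stand for higher solubility and lower numbers for lower solubility:
- compound 1 `CN(C)CCCNc1n[n+]([O-])c2ccccc2[n+]1[O-]`: 38000000 nM
- compound 2 `[O-][n+]1nc(NCCN2CCCCC2)[n+]([O-])c2ccccc21`: > 49000000 nM, a limit
- compound 3 `CCCN(CCC)CCNc1n[n+]([O-])c2ccccc2[n+]1[O-]`: > 25000000 nM, a limit

Compound 2 has no exact number and stands only at a limit: the limit of > 49000000 nM in this assay, at which 1 of the 3 values shown sits. Compound 3 is likewise known only as a limit: the limit of > 25000000 nM in this assay, at which 1 of the 3 values shown sits.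

Compound 4 `[O-][n+]1nc(NCCN2CCCCC2)[n+]([O-])c2cc(Cl)ccc21` keeps the side chain of compound 2 and carries chloro in place of hydrogen on an aromatic carbon.

The measured steps all lie on the side chain, and none touches an aromatic carbon. Going by the values given here, the only step with a readable size is an at least 1.2-fold higher number from compound 1 to compound 2 (0.11 log units; that floor lies within the scatter). The other two are a step that the limit leaves unreadable from compound 1 to compound 3 and a step that the two limits leave unreadable from compound 2 to compound 3. None of them therefore sizes the new change directly, and the expectation rests on judgement and carries a wide range.

Among the compounds with values here, compound 1, at 38000000 nM, holds the only exact number, so the expectation is anchored close to it. The expected change is an at least 1.6-fold lower number from compound 2 to compound 4 (0.21 log units; that floor lies within the scatter), an estimated move to a somewhat lower number in this assay, whose size stays loose since the starting point is a limit. A further limit as the reported result would not be surprising.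

For compound 4 the estimate is 30000000 nM, with an expected range from 8000000 nM to 70000000 nM.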

Compound 4, solubility: 3200000 nM
Compound 4: the middle estimate sits 9.4-fold (0.97 log units) above what was measured; measured number outside the range, below it.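

Notes on the series: in this assay, the aromatic carbon meta to a fused ring and para to a fused ring proves sensitive to substitution, with chloro in place of hydrogen giving an at least 15-fold lower number from compound 2 to compound 4 (1.18 log units; beyond the scatter) while the piperidin-1-yl side chain stays the same. All earlier steps lay on the side chain; the only readable one, an at least 1.2-fold higher number from compound 1 to compound 2 (0.11 log units; that floor lies within the scatter), stays within the scatter, and the other two cannot be read, so this is the first step in the series shown to lie beyond the scatter and the first on the aromatic ring. Compound 2 is known only as a limit, so the printed size of the step is a floor and the true change may be larger: the limit of > 49000000 nM in this assay, at which 1 of the 4 values shown sits.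

On these data alone, it remains open whether this large step belongs to chloro in particular or would also follow from another group on the same carbon, such as fluoro or methoxy. As far as these compounds go, it is also open whether chloro at this place gives a step of similar size with another side chain, such as the dimethylamino chain of compound 1 or the dipropylamino chain of compound 3.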